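Removing the ring from the amine: a smaller substituent

This account rests on a few compounds, and the source may have more. Where it says the series, first, only, none or still open, it means among the compounds named here.

Measured so far:
compound 1 `CN1CCN(c2cccc3c2ccn3S(=O)(=O)c2ccccc2)CC1`: 1 nM
compound 2 `O=S(=O)(c1ccccc1)n1ccc2c(N3CCCCC3)cccc21`: 128 nM

In an assay on isolated protein for displacement of a labelled ligand from 5-hydroxytryptamine receptor 6 (Homo sapiens), read by scintillation counting, with a stated time of 1 h (a lower number here means a stronger inhibitor, a higher number a weaker inhibitor), compound 2 gives the higher of the two numbers, standing well apart from compound 1, whose value in this assay is 1 nM. Among the measured compounds shown here, the only measured step, a 130-fold higher number from compound 1 to compound 2 (2.11 log units; beyond the scatter), came from swapping one ring amine for another. Compound 3 `CN(C)c1cccc2c1ccn2S(=O)(=O)c1ccccc1` differs from compound 2 in that (dimethylamino in place of piperidin-1-yl on an aromatic carbon). For the measured compounds named here, no measured step speaks to shrinking the ring to an open chain, so the expectation for this assay is a change from compound 2 to compound 3 staying within the scatter, estimated as a 1.2-fold higher number from compound 2 to compound 3 (0.07 log units; within the scatter). Compound 3 is therefore expected near 150 nM, between 40 nM and 600 nM.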

Compound 3, inhibition constant: 65 nM
Compound 3: the middle estimate sits 2.3-fold (0.36 log units) above what was measured, within the range that was stated.
By their numbers in this assay, from the lowest: compound 1; then compounds 3 and 2 (each within the scatter of the next).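

In this assay, replacing the piperidin-1-yl ring at this aromatic carbon with open-chain dimethylamino makes no difference beyond the scatter (a 2.0-fold lower number from compound 2 to compound 3 (0.29 log units; within the scatter)). The step from 4-methylpiperazin-1-yl remains large (a 65-fold higher number from compound 1 to compound 3 (1.81 log units; beyond the scatter)), so the earlier loss does not depend on the piperidin-1-yl ring alone. Nothing available explains why 4-methylpiperazin-1-yl stands apart. Still open, on these data alone, is whether its advantage comes from the ring's other nitrogen or the methyl on it. Piperazin-1-yl without the methyl, and morpholin-4-yl, would help separate these.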